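Methoxy added next to the phenol in compound 1

This account rests on a few compounds, and the source may have more. Where it says the series, first, only, none or still open, it means among the compounds named here.

Compound 1 `CC1=CC[C@H](C(C)(C)NC(=S)N/N=C/c2ccc(O)cc2)CC1` sits at a limit in an ADME assay on Vero cells (Chlorocebus sabaeus) for inhibition, read by sulforhodamine B assay, with a stated time of 48 h (a lower number here means a stronger inhibitor of growth, a higher number a weaker inhibitor of growth), where compound 1 gives > 100000 nM, so only a bound is known for it (the limit of > 100000 nM in this assay, at which 1 of the 2 values shown sits). Compound 2 `CC1=CC[C@H](C(C)(C)NC(=S)N/N=C/c2ccccc2O)CC1` in this assay gives 11200 nM; the shift an at least 8.9-fold lower number from compound 1 to compound 2 (0.95 log units; beyond the scatter) moves the hydroxy group, not the ring substitution. Compound 3 `COc1cc(/C=N/NC(=S)NC(C)(C)[C@H]2CC=C(C)CC2)ccc1O` differs from compound 1 by methoxy in place of hydrogen on an aromatic carbon. Going by the values given here, no measured step adds a group at this place, so no step beyond the scatter is expected, a modest drop at most. Compound 3 is therefore estimated at 80000 nM in this assay, a step of an at least 1.2-fold lower number from compound 1 to compound 3 (0.09 log units; that floor lies within the scatter).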

Compound 3, concentration for total growth inhibition: 91800 nM
Beside the measured number, compound 3's estimate is 1.1-fold (0.06 log units) below it; the range from low to high includes it.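

Methoxy in place of hydrogen on an aromatic carbon, ortho to a hydroxy group, gives an at least 1.0-fold lower number from compound 1 to compound 3 (0.03 log units; that floor lies within the scatter) in this assay. Going by these compounds alone, this is the first reading at this place, and it shows only a floor within the scatter, whereas the hydroxy move gave an at least 8.9-fold lower number from compound 1 to compound 2 (0.95 log units; beyond the scatter). Compound 1 stands at a limit and not at a number, so the true size of the step stays unknown: the limit of > 100000 nM in this assay, at which 1 of the 3 values shown sits.

As far as these compounds go, whether an amine or an ethoxy group on this aromatic carbon would shift the number remains open. So does whether methoxy acts the same way on the 2-hydroxyphenyl of compound 2.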